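Working notes: from compound 2 to compound 3

A few compounds are considered here, and "the series" means these few. Any claim that something is new, unique, unknown or untested is made for them only; others in the source may bear on it.

Measured so far in a functional assay on MDA-MB-231 cells (Homo sapiens) for cytotoxicity, read by MTT assay, with a stated time of 48 h; a lower number here means a stronger inhibitor, a higher number a weaker inhibitor
compound 1 (`COc1ccc(Nc2nc(-c3cccc(F)c3)nc3ccc(F)cc23)cc1`) gives 47300 nM
compound 2 (`Oc1cccc(Nc2nc(-c3cccc(F)c3)nc3ccc(F)cc23)c1`) gives > 50000 nM as a limit

Compound 2 stands only at a limit (> 50000 nM). Compound 3 (`Cc1cccc(Nc2nc(-c3cccc(F)c3)nc3ccc(F)cc23)c1`) carries methyl in place of hydroxy on an aromatic carbon, meta to a large group (methyl in place of hydroxy on an aromatic carbon). Within the data shown here, the only measured step (an at least 1.0-fold higher number from compound 1 to compound 2 (0.02 log units; that floor lies within the scatter)) also changes the 3-hydroxyphenyl group, but it shows no size beyond the scatter and gives only a loose guide. Expected in this assay is a step of no size beyond the scatter and in no set direction (an at least 1.1-fold lower number from compound 2 to compound 3 (0.04 log units; that floor lies within the scatter)). Estimated value: compound 3 at 45000 nM (expected range 18000 nM to 90000 nM).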

Compound 3, half-maximal inhibitory concentration: > 50000 nM
Compound 3: no number, only a limit (the forecaster's own chance of this, stated with the estimate: 45%); at least 1.1-fold (0.04 log units) between middle value and limit.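

In this assay compound 3 gives > 50000 nM as a limit of the assay, so methyl at this aromatic carbon, like hydroxy, yields no number. The change to 3-methylphenyl on the nitrogen gives an at least 1.0-fold higher number from compound 1 to compound 3 (0.02 log units; that floor lies within the scatter) and so shows no difference beyond the scatter. The step between compound 2 and compound 3 cannot be read, and the two groups cannot be ranked here: the limit of > 50000 nM in this assay, at which 2 of the 3 values shown sit.

Open, going by these compounds, is whether an amine, a carboxylic acid or a longer chain at this aromatic carbon would give a number rather than a limit.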